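The source may hold more compounds than are shown below. What is called first, only, known or untested is meant among the compounds shown, and "the series" means these compounds.

For the measured compounds named here, in an ADME assay on cells (Hepatocyte, Mus musculus) for metabolic stability (on this read-out lower numbers stand for a shorter-lived compound and higher numbers for a longer-lived compound), compound 3 (`O=C(OC1CCC(CN2CCN(c3cc(=O)c4cc(C(F)(F)F)cc([N+](=O)[O-])c4s3)CC2)CC1)c1ccncc1`) gives 0.0817 h as the only actual number so far. Compound 1 (`O=c1cc(N2CCN(CC3CCC(NS(=O)(=O)c4ccccc4)CC3)CC2)sc2c([N+](=O)[O-])cc(C(F)(F)F)cc12`) sits at > 1.55 h as a limit of the assay. Compound 2 (`O=C(NC1CCC(CN2CCN(c3cc(=O)c4cc(C(F)(F)F)cc([N+](=O)[O-])c4s3)CC2)CC1)c1ccccc1`) sits at > 1.55 h as a limit too. Two large steps reach compound 3, namely an at least 18-fold lower number from compound 1 to compound 3 (1.27 log units; beyond the scatter) and an at least 18-fold lower number from compound 2 to compound 3 (1.27 log units; beyond the scatter) and both put ((pyridin-4-yl)carbonyl)oxy on a saturated ring carbon. Compound 4 (`CC(=O)OC1CCC(CN2CCN(c3cc(=O)c4cc(C(F)(F)F)cc([N+](=O)[O-])c4s3)CC2)CC1`) differs by methyl in place of pyridin-4-yl on a carbonyl carbon and keeps that oxy attachment, now as acetoxy. Going by the values given here, no measured step changes this group alone, so neither large step is expected to repeat, and compound 4 is expected to stay close to compound 3 at 0.0817 h in this assay with no direction favoured. The expected move is a 1.2-fold higher number from compound 3 to compound 4 (0.09 log units; within the scatter) and stays within the scatter. For compound 4 the estimated half-life is 0.1 h with an expected range of 0.04 h to 0.3 h in this read-out.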

Compound 4, half-life: < 0.15 h
Compound 4: a limit, no number; the forecaster's own chance of this, stated with the estimate: 10%; the middle value lies beyond the limit too.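

Replacing pyridin-4-yl with methyl still leaves the ester on the saturated ring carbon far from the amide and the sulfonamide in this assay (an at least 10-fold lower number from compound 2 to compound 4 (1.01 log units; beyond the scatter)) and (an at least 10-fold lower number from compound 1 to compound 4 (1.01 log units; beyond the scatter)). The short half-life of compound 3 therefore does not require the pyridin-4-yl ring. Compound 4 carries a limit, and the step from compound 3 to compound 4 cannot be read.

Open, going by these compounds, is whether an ether or a carbamate on that ring carbon would group with the esters or with compound 1 and compound 2. Also open, on these data alone, is how a pivaloyl ester would compare with compound 3 and compound 4.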